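The source may hold more compounds than are shown below. What is called first, only, known or untested is meant among the compounds shown, and "the series" means these compounds.

Of the compounds shown here, three built on one shared core have so far been tested in a functional assay on the whole organism (Tail, strain ICR) with Mus musculus as the target, in the tail flick test, with a stated time of 150 min, at a dose of 25 umol/kg by the oral route; a lower number here means a weaker effect, a higher number a stronger effect of the compound at the dose given. In this assay compound 1 `O=C(CN(c1nc(Cl)nc2[nH]cnc12)C1CC1)NCC(=O)OCc1ccccc1` gives 18%, compound 2 `CC(C)[C@H](NC(=O)CN(c1nc(Cl)nc2[nH]cnc12)C1CC1)C(=O)OCc1ccccc1` gives 17.9%, and compound 3 `O=C(CN(c1nc(Cl)nc2[nH]cnc12)C1CC1)N[C@@H](CC(=O)OCc1ccccc1)C(=O)OCc1ccccc1` gives 6.68%. Compound 3 therefore stands lowest of the three: a number 11.3 percentage points lower from compound 1 to compound 3 (beyond the scatter) and a number 11.2 percentage points lower from compound 2 to compound 3 (beyond the scatter), whereas a number 0.1 percentage points lower from compound 1 to compound 2 (within the scatter).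

Compound 4 `O=C(CN(c1nc(Cl)nc2[nH]cnc12)C1CC1)N[C@@H](CCC(=O)OCc1ccccc1)C(=O)OCc1ccccc1` differs from compound 3 in a single place. (benzyloxycarbonyl)methyl in place of benzyloxycarbonyl on a saturated chain carbon, two bonds along the chain from an amide-type nitrogen and a carbonyl carbon Put simply, the same ester-bearing chain is kept but made one carbon longer.

Neither measured step is a true match for this change. The two steps that lead to compound 3 each swap a small group for a (benzyloxycarbonyl)methyl group, and both were modest, beyond the scatter. Lengthening a chain that is already present has no counterpart among the measured pairs, so no step beyond the scatter is expected in this assay in either direction. The step from compound 3 to compound 4 is accordingly estimated as a number 1.3 percentage points higher from compound 3 to compound 4 (within the scatter). Compound 4 is expected to give about 8%, with a likely range from 0% to 20%.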

Compound 4, a percentage reported as activity, at one dose (the size of the read-out at that dose, not a potency): 44.5%
Compound 4: the middle estimate sits 36.5 percentage points below what was measured; the measured number lies above the stated range.
By their numbers in this assay, from the lowest: compound 3; then compounds 2 and 1 (each within the scatter of the next); then compound 4.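

On the saturated chain carbon, two bonds along the chain from an amide-type nitrogen and a carbonyl carbon, one added chain carbon turns (benzyloxycarbonyl)methyl into 2-(benzyloxycarbonyl)ethyl, and this assay shows a number 37.8 percentage points higher from compound 3 to compound 4 (beyond the scatter) for that small change. The earlier compounds shown here gave no sign that the longer ester-bearing chain could outperform smaller groups, yet the comparisons with hydrogen and isopropyl show a number 26.5 percentage points higher from compound 1 to compound 4 (beyond the scatter) and a number 26.6 percentage points higher from compound 2 to compound 4 (beyond the scatter), which places compound 4 highest of the four and shows that the length of this chain, and not merely the presence of a benzyl ester on it, goes with the size of the read-out. Nothing available accounts for why a single carbon is linked to so large a step.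

For the compounds shown here, with only two lengths of this chain compared, it remains open whether a longer chain such as 3-(benzyloxycarbonyl)propyl would raise the number further or lower it. On these data alone, it is also open whether the benzyl ester itself is needed at this length, which a free carboxylic acid or a methyl ester at the end of the same chain could help to settle.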